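From 4-methoxyphenyl to hydroxymethyl: what happens to growth inhibition?

The source may report more compounds than this note shows. Statements on the series, on what has been measured and on what is new or still open speak of the compounds shown alone.

- Compound 1 `CCCCCc1ccc(-c2cn(CCCN3C(=O)COc4ccccc43)nn2)cc1`: > 100000 nM
- Compound 2 `COc1ccc(-c2cn(CCCN3C(=O)COc4ccccc43)nn2)cc1`: 4900 nM

Going by the values given here, in a functional assay on HeLa cells (Homo sapiens) for antiproliferative activity, read by sulforhodamine B assay, with a stated time of 48 h (on this read-out lower numbers stand for stronger inhibition of growth and higher numbers for weaker inhibition of growth), compound 2 gives 4900 nM, the only exact number so far. Compound 1 reads > 100000 nM, which is a limit. Compound 3 `O=C1COc2ccccc2N1CCCn1cc(CO)nn1` carries hydroxymethyl in place of 4-methoxyphenyl on an aromatic carbon. Among the compounds with values here, one measured step bears on this: an at least 20-fold lower number from compound 1 to compound 2 (1.30 log units; beyond the scatter). Within the data shown here, it shows that a change within this group can move the number a long way, although no measured compound lacks the ring. A sizeable move to weaker inhibition in this assay is therefore expected, an 8.2-fold higher number from compound 2 to compound 3 (0.91 log units; beyond the scatter). For compound 3 the estimated value is 40000 nM, with an expected range of 9000 nM to 100000 nM.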

Compound 3, concentration for 50% growth inhibition: 7300 nM
Estimate against measurement, compound 3: 5.5-fold (0.74 log units) above, outside the stated range (below it).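

In this assay, hydroxymethyl in place of 4-methoxyphenyl gives a 1.5-fold higher number from compound 2 to compound 3 (0.17 log units; within the scatter), so this position tolerates losing the whole aromatic ring with no change in growth inhibition beyond the scatter. The ring is therefore not needed to reach this level of growth inhibition, something the earlier step, a change made on that ring, could not show. Compound 1 remains a limit, not a number: the limit of > 100000 nM in this assay, at which 1 of the 3 values shown sits.

On these data alone, whether an amine, a carboxylic acid or a longer chain ending in hydroxyl would hold this level at the same position stays open.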